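The compounds below may be only part of what the source reports. "The series", "measured", "known", "first", "only" and "open" are said of these compounds alone.

Among the measured compounds shown here, in a functional assay on HCT-116 cells (Homo sapiens) for cytotoxicity, read by MTT assay, with a stated time of 72 h (a higher number here means a weaker inhibitor, a lower number a stronger inhibitor), compound 2 `CCOC(=O)C1=C(C)NC(=O)NC1c1cn(C(=O)CNc2ccc([N+](=O)[O-])cc2C)c2ccccc12` gives 600 ug/mL, the higher of the two numbers so far, while compound 1 `CCOC(=O)C1=C(C)NC(=O)NC1c1cn(C(=O)CNc2ccc([N+](=O)[O-])cc2Cl)c2ccccc12` gives 5 ug/mL. For the measured compounds named here, the only step known, a 120-fold higher number from compound 1 to compound 2 (2.08 log units; beyond the scatter), concerns methyl in place of chloro on an aromatic carbon and is large. Going by the values given here, compound 3 `CCOC(=O)C1=C(C)NC(=O)NC1c1cn(C(=O)CNc2ccccc2[N+](=O)[O-])c2ccccc12` carries 2-nitrophenyl in place of 2-methyl-4-nitrophenyl on an amine nitrogen; no measured step tests this change, so the single large step bears on it only loosely, and a number lower than that of compound 2 seems likely, with wide uncertainty. Compound 3 is expected near 100 ug/mL, in the range 10 ug/mL to 600 ug/mL. The expected step is a 6.0-fold lower number from compound 2 to compound 3 (0.78 log units; beyond the scatter).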

Compound 3, half-maximal inhibitory concentration: 250 ug/mL
The estimate for compound 3 lay 2.5-fold (0.40 log units) below the measured number; the range from low to high includes it.
By their numbers in this assay, from the lowest: compound 1; then compound 3; then compound 2.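

On the amine nitrogen, 2-nitrophenyl in place of 2-methyl-4-nitrophenyl gives only a modest change in this assay, a 2.4-fold lower number from compound 2 to compound 3 (0.38 log units; beyond the scatter). The same group in place of 2-chloro-4-nitrophenyl gives a large change, a 50-fold higher number from compound 1 to compound 3 (1.70 log units; beyond the scatter), so among these three compounds the low number goes only with 2-chloro-4-nitrophenyl. No supporting data explain either step.

On these data alone, it remains open whether the chloro and nitro groups are both needed for that low number. A 2-chlorophenyl or a 2-bromo-4-nitrophenyl group at this position would test this.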